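Chloromethyl to aminomethyl in the Vero 76 cytotoxicity series

The source may hold more compounds than are shown below. What is called first, only, known or untested is meant among the compounds shown, and "the series" means these compounds.

Compound 1 `CC(C)[C@@H](Nc1nc(Cl)nc2c1ncn2[C@H]1[C@H](O)[C@H](O)[C@]2(CCl)C[C@H]12)C1CC1`: 27000 nM
Compound 2 `CC(C)(O)[C@@H](Nc1nc(Cl)nc2c1ncn2[C@H]1[C@H](O)[C@H](O)[C@]2(CO)C[C@H]12)C1CC1`: > 100000 nM (a limit of the assay)

Within the data shown here, in an ADME assay on Vero 76 cells (Chlorocebus sabaeus) for cytotoxicity, read by neutral red uptake (a higher number here means that more compound is tolerated, a lower number that less compound is tolerated), compound 1 gives 27000 nM, the only actual number so far. Compound 2 gives > 100000 nM, which is a limit and not a number.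

The next compound to be read is compound 3 `CC(C)[C@@H](Nc1nc(Cl)nc2c1ncn2[C@H]1[C@H](O)[C@H](O)[C@]2(CN)C[C@H]12)C1CC1`. It differs from compound 1 by amino in place of chloro on a saturated chain carbon bound to a saturated ring carbon. The same difference, seen one bond further out, is chloromethyl to aminomethyl. Among the measured compounds shown here, no measured step isolates a change of this kind, so any forecast is loose.

A moderate move in this assay is expected, towards more compound tolerated. The expectation leans on compound 2, which also lacks the chloromethyl and reads > 100000 nM, a limit. The expected size of the change is a 1.9-fold higher number from compound 1 to compound 3 (0.27 log units; within the scatter). For compound 3 the estimated value is 50000 nM, with an expected range of 15000 nM to 100000 nM.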

Compound 3, half-maximal cytotoxic concentration: 32000 nM
The estimate for compound 3 lay 1.6-fold (0.19 log units) above the measured number; measured number inside the range.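

In this assay, amino in place of chloro on a saturated chain carbon bound to a saturated ring carbon gives a 1.2-fold higher number from compound 1 to compound 3 (0.07 log units; within the scatter). Among these compounds, this is the first step that isolates this position, and chloromethyl to aminomethyl leaves the read-out within the scatter, even though a chlorine gives way to a nitrogen and the amino group brings a hydrogen-bond donor and a hydrogen-bond acceptor that the chloro does not have. On this core and with this side chain, the chloro can therefore be exchanged for amino with no readable shift in this assay, so this pair gives no sign that the chloro on its own sets the level of the number.

Among the compounds shown here, compound 2 remains a limit and not a number, and it differs from the other compounds in more than one place, so no step to it can be read: the limit of > 100000 nM in this assay, at which 1 of the 3 values shown sits. Still open is how a carboxylic acid, or a longer chain carrying the amine, would read at this same place on the core of compound 1 in this assay.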